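Swapping a Dichlorophenyl for a Methylphenyl Group

The compounds below may be only part of what the source reports. "The series", "measured", "known", "first", "only" and "open" are said of these compounds alone.

Compound 1 `Cc1cc(NC(=O)Cn2nnc(-c3ccccc3)n2)n(C2CCS(=O)(=O)CC2)n1`: > 10000 nM
Compound 2 `CC1CC1c1cc(NC(=O)Cn2nnc(-c3ccccc3)n2)n(C2CCCCC2)n1`: 843 nM
Compound 3 `Cc1cc(NC(=O)Cn2nnc(-c3cc(Cl)cc(Cl)c3)n2)n(C2CCCCC2)n1`: 980 nM

In an assay on HEK293 cells for activation of Kir3.1/Kir3.2 (Homo sapiens), read by thallium flux (a lower number here means that less compound is needed, a higher number that more compound is needed for the effect), compound 1 gives > 10000 nM, which is a limit of the assay rather than a number. Compound 2 gives 843 nM in this assay. Compound 3 gives 980 nM, the higher of the two numbers, but its nearest neighbour, compound 2, lies within the usual scatter, so no order can be read between them. Compound 4 `Cc1cccc(-c2nnn(CC(=O)Nc3cc(C)nn3C3CCCCC3)n2)c1` has not yet been measured. It differs from compound 3 in one place: 3-methylphenyl in place of 3,5-dichlorophenyl on an aromatic carbon. Among the measured compounds shown here, no step between two measured compounds bears on this change, so its size cannot be derived from the data. A step no larger than the scatter, in either direction, is expected. The estimate for compound 4 is 1500 nM, between 500 nM and 5000 nM. This corresponds to an expected step of a 1.5-fold higher number from compound 3 to compound 4 (0.18 log units; within the scatter).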

Compound 4, half-maximal effective concentration: 129 nM
The estimate for compound 4 lay 12-fold (1.07 log units) above the measured number; measured number below the stated range.
By their numbers in this assay, from the lowest: compound 4; then compounds 2 and 3 (each within the scatter of the next). At a limit, above all of these: compound 1.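

In this assay, putting 3-methylphenyl in place of 3,5-dichlorophenyl on the aromatic carbon between two ring nitrogen atoms gives a 7.6-fold lower number from compound 3 to compound 4 (0.88 log units; beyond the scatter), a step beyond the scatter. Among the compounds shown here, the earlier compounds offered no step between measured compounds, so this is the first sign that the number responds to a change of the aryl group at this position. Nothing measured here bears on the reason for this step. Left open is whether the step follows the loss of the chlorine atoms or the arrival of the methyl. A plain phenyl or a 3-chlorophenyl at this place on the same core would separate the two.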